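Cytotoxicity of the Unsubstituted Phenyl Analogue

The compounds below may be only part of what the source reports. "The series", "measured", "known", "first", "only" and "open" are said of these compounds alone.

Of the compounds shown here, three sharing one core have been tested in an ADME assay on Vero cells (Chlorocebus sabaeus) for cytotoxicity; on this read-out higher numbers stand for lower toxicity in this test and lower numbers for higher toxicity in this test. Compound 1 `Fc1ccc(-c2nn3c(NC4CCCC4)cccc3c2-c2ccnc(NC3CCCC3)n2)cc1` carries a fluoro group on its pendant aromatic ring, and in this assay compound 1 gives > 160000 nM, which is a limit of the assay rather than a number. Compound 2 `COc1ccc(-c2nn3c(NC4CCCC4)cccc3c2-c2ccnc(NC3CCCC3)n2)cc1` has a methoxy group in that place, and in this assay compound 2 gives > 100000 nM, again only a limit. Compound 3 `c1cc(NC2CCCC2)n2nc(-c3ccc(OCC4CC4)cc3)c(-c3ccnc(NC4CCCC4)n3)c2c1` bears a cyclopropylmethoxy group, and in this assay compound 3 gives > 40000 nM, also a limit. Compound 3 thus stands with the other two at the edge of what the assay can report, and the steps a step that the two limits leave unreadable from compound 1 to compound 3, a step that the two limits leave unreadable from compound 2 to compound 3 and a step that the two limits leave unreadable from compound 1 to compound 2 cannot be read in size, each end resting at a limit (the limit of > 100000 nM in this assay, at which 1 of the 3 values shown sits, (the limit of > 160000 nM in this assay, at which 1 of the 3 values shown sits), (the limit of > 40000 nM in this assay, at which 1 of the 3 values shown sits)).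

Compound 4 `c1ccc(-c2nn3c(NC4CCCC4)cccc3c2-c2ccnc(NC3CCCC3)n2)cc1` is the change (hydrogen in place of cyclopropylmethoxy on an aromatic carbon). Among the measured compounds shown here, the expected step that the limit leaves unreadable from compound 3 to compound 4 is none beyond the scatter, with no measured step readable in size to point another way. Compound 4 is expected to stay at or near a limit of the assay. The estimate for compound 4 in this assay is 100000 nM, with a range from 40000 nM to 300000 nM.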

Compound 4, half-maximal cytotoxic concentration: > 40000 nM
Compound 4 gave a limit, no number; the forecaster's own chance of this, stated with the estimate: 85%; the middle value is on the limit's open side.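

In this assay compound 4 gives > 40000 nM, which is a limit and not a number. Its steps from compound 1, compound 2 and compound 3 cannot be read in size, because each end rests on a limit: the limit of > 40000 nM in this assay, at which 2 of the 4 values shown sit.

The compounds shown leave open whether the group on the pendant aromatic ring changes this read-out at all.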